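The source may hold more compounds than are shown below. What is called first, only, known or untested is meant among the compounds shown, and "the series" means these compounds.

Working notes on the series in an ADME assay (liver) for metabolic stability, with Liver microsome (Canis lupus familiaris) as the target, read by LC-MS, using microsomes, with a stated time of 30 min, tested at 4 uM; a lower number here means that less of the compound is left, a higher number that more of the compound is left. Compound 1 (`CC(=O)NCCn1c(-c2ccccc2Cl)nc2c(N3CCN(C)CC3)nc(C)nc21`) gives 40% and compound 2 (`Cc1nc(N2CCN(C)CC2)c2nc(-c3ccccc3Cl)n(C3CC3)c2n1`) gives 98% on the same read-out. Compound 3 (`Cc1nc(N2CCN(C)CC2)c2nc(-c3cccc(C(F)(F)F)c3)n(C3CCOCC3)c2n1`) gives 44% and is second of the three numbers, although it cannot be told apart from compound 1 within the scatter. Compound 2 lies far beyond the scatter from compound 3.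

The step under consideration leads to compound 4 (`COc1ccc(-c2nc3c(N4CCN(C)CC4)nc(C)nc3n2C2CCOCC2)c(C)c1`), with 4-methoxy-2-methylphenyl in place of 3-(trifluoromethyl)phenyl on an aromatic carbon. The oxan-4-yl group stays in place.

Within the data shown here, the only measured step is a number 58 percentage points higher from compound 1 to compound 2 (beyond the scatter) and it sits on an aromatic nitrogen, not on the aromatic carbon that changes here. Among the measured compounds shown here, no measured pair isolates a change at this aromatic carbon, so that step gives no direct size or direction. It does show that a single change in this series can move the number a long way, which argues for a wide range.

The estimated change in this assay is a number 6 percentage points lower from compound 3 to compound 4 (within the scatter) and it is expected to stay within the scatter, with its direction only weakly held. The expected value for compound 4 is 38% (estimated range 15% to 65%).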

Compound 4, percent of the compound remaining: 41%
For compound 4 the middle estimate is 3 percentage points below the measured one; the range from low to high includes it.
By their numbers in this assay, from the lowest: compounds 1, 4 and 3 (each within the scatter of the next); then compound 2.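

In this assay, among these compounds, the first measured step at this aromatic carbon, a number 3 percentage points lower from compound 3 to compound 4 (within the scatter), does not separate the two compounds, with the oxan-4-yl group held in place. The two aryl groups differ in their substituents, and the entering 4-methoxy-2-methylphenyl brings an oxygen and a hydrogen-bond acceptor that 3-(trifluoromethyl)phenyl lacks, yet this exchange leaves no readable mark on the read-out, whereas the step on an aromatic nitrogen, a number 58 percentage points higher from compound 1 to compound 2 (beyond the scatter), lies beyond the scatter. No measurement at hand bears on why the number holds here.

Going by these compounds, it remains open whether this exchange would also leave the number in place with cyclopropyl instead of the oxan-4-yl group, since the two aryl groups have been compared only with oxan-4-yl present. On these data alone, it is equally open whether a phenyl group carrying a primary amine or a carboxylic acid, or a longer alkyl chain in place of the aryl group, would shift the number at this aromatic carbon by an amount beyond the scatter.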